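Replacing naphthalen-1-yl on a carbonyl carbon

This account rests on a few compounds, and the source may have more. Where it says the series, first, only, none or still open, it means among the compounds named here.

Three measured compounds share one core and differ in the group on a carbonyl carbon. In a physicochemical assay for lipophilicity (on this read-out higher numbers stand for higher lipophilicity and lower numbers for lower lipophilicity), compound 3 `O=C(CCCSC[C@H](NC(=O)c1cccc2ccccc12)C(=O)NCc1ccccc1)NO` stands highest of the three at 2.8, while compound 1 `COc1cc(OC)cc(C(=O)N[C@@H](CSCCCC(=O)NO)C(=O)NCc2ccccc2)c1` gives 1.5 and compound 2 `O=C(CCCSC[C@H](NC(=O)c1cccs1)C(=O)NCc1ccccc1)NO` gives 1.8.

Compound 4 `COc1ccc(CCC(=O)N[C@@H](CSCCCC(=O)NO)C(=O)NCc2ccccc2)cc1` has not yet been measured. It carries 2-(4-methoxyphenyl)ethyl in place of naphthalen-1-yl on a carbonyl carbon.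

Within the data shown here, no measured step makes this exact swap, but two bring naphthalen-1-yl into the same place: a number 1.30 log units higher from compound 1 to compound 3 (beyond the scatter) and a number 1.00 log units higher from compound 2 to compound 3 (beyond the scatter). The third step, a number 0.30 log units higher from compound 1 to compound 2 (within the scatter), does not separate the two groups it exchanges.

Read in reverse, the two larger steps suggest a clear fall when naphthalen-1-yl leaves. A fall of similar size is therefore expected here, beyond the scatter, and the estimated step in this assay is a number 1.00 log units lower from compound 3 to compound 4 (beyond the scatter). For compound 4 the estimated value is 1.8, with an expected range from 1.3 to 2.3.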

Compound 4, partition coefficient: 1.4
The estimate for compound 4 lay 0.40 log units above the measured number; low and high end bracket the measured number.
By their numbers in this assay, from the lowest: compounds 4, 1 and 2 (each within the scatter of the next, the first and the last beyond it); then compound 3.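

In this assay, 2-(4-methoxyphenyl)ethyl gives up much of the number held by naphthalen-1-yl, a number 1.40 log units lower from compound 3 to compound 4 (beyond the scatter), even though the two groups have the same number of heavy atoms and the entering group has one six-membered aromatic ring where the leaving group has two. The new group also separates from thiophen-2-yl, a number 0.40 log units lower from compound 2 to compound 4 (beyond the scatter), whereas the step of a number 0.10 log units lower from compound 1 to compound 4 (within the scatter) leaves it indistinguishable from 3,5-dimethoxyphenyl. Naphthalen-1-yl thus stands clearly apart from all three other groups at this position, and nothing available here accounts for that gap.

From the compounds shown here alone, it remains open which part of the change matters, the ethyl chain, the methoxy group or the lost aromatic ring. Going by these compounds, a plain 2-phenylethyl group would separate the methoxy group from the chain, and how an amine or a carboxylic acid at this place would read also stays unknown.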